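Amide side chains on a shared core: estimate for compound 4

The source may hold more compounds than are shown below. What is called first, only, known or untested is meant among the compounds shown, and "the series" means these compounds.

Three compounds share one core and differ only in the amide side chain. In a functional assay on MCF7 cells (Homo sapiens) for cytotoxicity, read by MTT assay, with a stated time of 24 h, tested at 32 ug/mL (a higher number here means a stronger effect of the compound at the concentration tested, a lower number a weaker effect), compound 1 `Cn1c(-c2ccc(NC(=O)CSc3nc4cc(Cl)ccc4o3)cc2)nc(-c2ccccc2)c1-c1ccccc1` gives 59.7%, compound 2 `Cn1c(-c2ccc(NC(=O)CSC3=NCCS3)cc2)nc(-c2ccccc2)c1-c1ccccc1` gives 52.5%, and compound 3 `CCN1CCN(CC(=O)Nc2ccc(-c3nc(-c4ccccc4)c(-c4ccccc4)n3C)cc2)CC1` gives 38.6%, the lowest of the three; the gaps to the others read a number 13.9 percentage points lower from compound 2 to compound 3 (beyond the scatter) and a number 21.1 percentage points lower from compound 1 to compound 3 (beyond the scatter). Compound 4 `COc1ccc(CN2CCN(CC(=O)Nc3ccc(-c4nc(-c5ccccc5)c(-c5ccccc5)n4C)cc3)CC2)cc1` carries 4-methoxyphenyl in place of methyl on a saturated chain carbon bound to an amine nitrogen in a ring. Within the data shown here, no measured step touches this place: the steps of a number 7.2 percentage points lower from compound 1 to compound 2 (within the scatter), a number 21.1 percentage points lower from compound 1 to compound 3 (beyond the scatter) and a number 13.9 percentage points lower from compound 2 to compound 3 (beyond the scatter) each exchange the whole group on the saturated chain carbon bound to the carbonyl carbon, not the group on the ring nitrogen. No step beyond the scatter is therefore expected in either direction. Compound 4 is estimated at 42%, with a range of 28% to 58%. The expected step is a number 3.4 percentage points higher from compound 3 to compound 4 (within the scatter).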

Compound 4, a percentage reported as activity, at one concentration (the size of the read-out at that concentration, not a potency): 17.7%
For compound 4 the middle estimate is 24.3 percentage points above the measured one; measured number outside the range, below it.
By their numbers in this assay, from the lowest: compound 4; then compound 3; then compounds 2 and 1 (each within the scatter of the next).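

In this assay, the place on a saturated chain carbon bound to an amine nitrogen in a ring is not silent: 4-methoxyphenyl in place of methyl gives a number 20.9 percentage points lower from compound 3 to compound 4 (beyond the scatter). The read-out therefore depends on more than the exchange of the whole group on the saturated chain carbon bound to a carbonyl carbon, since a change within the 4-ethylpiperazin-1-yl group also shifts it beyond the scatter. Nothing available accounts for this step.

Open, as far as these compounds go, is whether the step belongs to the aromatic ring or to the methoxy group. An unsubstituted benzyl or a butyl chain in the same place would separate these readings.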